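This account rests on a few compounds, and the source may have more. Where it says the series, first, only, none or still open, it means among the compounds named here.

Compound 1 `Nc1nc([SeH])nc2ncccc12` and compound 3 `Nc1nc([SeH])nc2ccccc12` share a selenium bearing a hydrogen, and differ in their cores; the difference between the two cores is not broken down here. In a functional assay on HT-29 cells (Homo sapiens) for cytotoxicity, read by MTT assay, with a stated time of 72 h (a lower number here means a stronger inhibitor of growth, a higher number a weaker inhibitor of growth), compound 1 gives 89600 nM. Compound 3 reaches only a limit of this assay, giving > 100000 nM. Compound 2 `CCCCC[Se]c1nc(N)c2cccnc2n1` carries the change (pentyl in place of hydrogen on a selenium); in this assay compound 2 gives 20000 nM, a step of a 4.5-fold lower number from compound 1 to compound 2 (0.65 log units; beyond the scatter). Compound 4 `CCCCC[Se]c1nc(N)c2ccccc2n1` is not yet measured and carries the same change, (pentyl in place of hydrogen on a selenium), on the core of compound 3. Because compound 3 sits at the limit of > 100000 nM in this assay, at which 1 of the 3 values shown sits, its true value is not known, and the step to compound 4 can only be guessed. Pentyl in place of hydrogen on the selenium made a modest step from compound 1 to compound 2, and a step of similar kind is expected here: for compound 4 the expectation is an at least 2.0-fold lower number from compound 3 to compound 4 (0.30 log units; that floor lies within the scatter). Compound 4 is therefore estimated at 50000 nM, with a range from 15000 nM to 200000 nM.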

Compound 4, concentration for total growth inhibition: > 100000 nM
Compound 4: only a limit was reported; the forecaster's own chance of this, stated with the estimate: 35%; at least 2.0-fold (0.30 log units) between middle value and limit.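

No step can be read from compound 3 to compound 4, since each gives only a limit in this assay: the limit of > 100000 nM in this assay, at which 2 of the 4 values shown sit.

The compounds shown leave open whether pentyl in place of hydrogen on a selenium changes growth inhibition at all on the core of compound 3, as it does on the core of compound 1.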